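The source may hold more compounds than are shown below. What is called first, only, known or untested is meant among the compounds shown, and "the series" means these compounds.

Measured so far in an ADME assay on BHK-21 cells (Mesocricetus auratus) for cytotoxicity, read by MTT assay; a higher number here means that more compound is tolerated, a lower number that less compound is tolerated:
Compound 1 `CC(=O)c1ccc2c(c1)nc(-c1ccc(Cl)cc1)n2C1CCCCC1`: > 100000 nM, a limit of the assay and not a number
Compound 2 `CC(=O)c1ccc2c(c1)nc(-c1ccc(C(F)(F)F)cc1)n2C1CCCCC1`: 33000 nM

Among the compounds with values here, compound 2, at 33000 nM, is the only compound here with an exact number, so it cannot yet be ranked within a spread of values. The next compound is compound 3 `C/C(=N\NC(N)=O)c1ccc2c(c1)nc(-c1ccc(C(F)(F)F)cc1)n2C1CCCCC1`, which keeps the shared core and the trifluoromethyl group. Its change is at the acetyl group: a group of 7 heavy atoms (3 carbon, 3 nitrogen, 1 oxygen; no ring) in place of a group of 3 heavy atoms (2 carbon, 1 oxygen; no ring), on an aromatic carbon. Within the data shown here, the only measured step, an at least 3.0-fold lower number from compound 1 to compound 2 (0.48 log units; beyond the scatter), came from trifluoromethyl in place of chloro, a change elsewhere in the molecule. It therefore says nothing direct about replacing acetyl, although it shows that swapping one group can move this assay beyond the scatter. Among the measured compounds shown here, no measured step touches the acetyl group, so the direction remains open and the expectation is weak. The expected change is a 1.4-fold higher number from compound 2 to compound 3 (0.13 log units; within the scatter), which would not stand clear of the scatter. For compound 3 the estimated value is 45000 nM, with an expected range of 15000 nM to 100000 nM.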

Compound 3, half-maximal cytotoxic concentration: > 100000 nM
Compound 3: only a limit was reported; the forecaster's own chance of this, stated with the estimate: 35%; middle value at least 2.2-fold (0.34 log units) away from the limit.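

In this assay, this aromatic carbon now has a measured step of its own: the group of 7 heavy atoms, a chain carrying hydrogen-bond donors where acetyl has none, in place of acetyl gives an at least 3.0-fold higher number from compound 2 to compound 3 (0.48 log units; beyond the scatter). Within the data shown here, the earlier step showed only that a change at the chloro and trifluoromethyl site can move the number, and it moved it the other way, with an at least 3.0-fold lower number from compound 1 to compound 2 (0.48 log units; beyond the scatter), so a change at the acetyl position can also move the number beyond the scatter, here towards more compound being tolerated. Compound 3 gives > 100000 nM, which is a limit of the assay and not a number, so the step has a lower bound only and its true size stays unknown: the limit of > 100000 nM in this assay, at which 2 of the 3 values shown sit.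

The compounds shown hold only acetyl and this one chain at the position, so they cannot tell whether the whole chain or only some part of it goes with the higher number. Also open, on these data alone, is whether an amine or a carboxylic acid on the same aromatic carbon would move the number in the same direction, and how far the trifluoromethyl compound's number could rise with such groups.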